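A few compounds are considered here, and "the series" means these few. Any claim that something is new, unique, unknown or untested is made for them only; others in the source may bear on it.

In a functional assay on KBVIN cells (Homo sapiens) for antiproliferative activity, read by sulforhodamine B assay, with a stated time of 3 days (a lower number here means that less compound is needed, a higher number that more compound is needed for the effect), compound 1 `CCC1=C(O)c2c(oc(-c3ccc(C(C)C)cc3)cc2=O)C(CC)(CC)C1=O` gives 1.08 uM, while compound 2 `CCCCc1ccc(-c2cc(=O)c3c(o2)C(CC)(CC)C(=O)C(CC)=C3O)cc1` gives 37 uM, the higher of the two numbers. Compound 3 `CCC1=C(O)c2c(oc(-c3ccc(CC(C)C)cc3)cc2=O)C(CC)(CC)C1=O` differs from compound 2 by one change: isopropyl in place of propyl on a saturated chain carbon bound to an aromatic carbon. Going by the values given here, only one measured step bears on this, the large 34-fold higher number from compound 1 to compound 2 (1.53 log units; beyond the scatter), with butyl in place of isopropyl on an aromatic carbon. With that single step as the guide, a moderate move towards a lower number, beyond the scatter, is expected, though with much uncertainty. The estimated change is a 4.6-fold lower number from compound 2 to compound 3 (0.67 log units; beyond the scatter). For compound 3 the expected value is 8 uM, within an estimated range of 1.5 uM to 40 uM.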

Compound 3, concentration for half-maximal effect: 17.4 uM
Compound 3: middle estimate off by 2.2-fold (0.34 log units), on the low side; the measured number falls inside the stated range.
By their numbers in this assay, from the lowest: compound 1; then compound 3; then compound 2.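

Butyl to isobutyl, the same atoms joined differently, gives a 2.1-fold lower number from compound 2 to compound 3 (0.33 log units; beyond the scatter), so in this assay branching this chain alone moves the number, though only modestly. Isobutyl in place of isopropyl still gives a 16-fold higher number from compound 1 to compound 3 (1.21 log units; beyond the scatter), a larger step, so among these three compounds branching recovers only a small part of the gap and the isopropyl group remains the best of the three. Nothing available explains why these groups differ.

On these data alone, whether a tert-butyl group, a cyclohexyl group or a longer chain on the same aromatic carbon would fit this order remains open.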